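Amide for amine on the shared core: antiproliferative outlook

The compounds below may be only part of what the source reports. "The series", "measured", "known", "first", "only" and "open" are said of these compounds alone.

Measured compounds:
compound 1 `CC(C)=CCC[C@]1(C)/C=C/[C@@H](OC(=O)C=C(C)C)[C@](C)(O)/C=C/C(=O)/C(CN(C(C)C)C(C)C)=C\C1`, 750 nM
compound 2 `CC(C)=CCC[C@]1(C)/C=C/[C@@H](OC(=O)C=C(C)C)[C@](C)(O)CCC(=O)/C(CO)=C\C1`, > 40000 nM
compound 3 `CC(C)=CCC[C@]1(C)/C=C/[C@@H](OC(=O)C=C(C)C)[C@](C)(O)/C=C/C(=O)/C(COC(=O)c2ccc([N+](=O)[O-])cc2)=C\C1`, 570 nM

In a functional assay on SW480 cells (Homo sapiens) for antiproliferative activity, read by MTT assay, with a stated time of 48 h (on this read-out higher numbers stand for weaker inhibition and lower numbers for stronger inhibition), compound 1 gives 750 nM, the highest of the two numbers shown. For compound 2 the result in this assay is a limit, > 40000 nM, not a number. Compound 3 gives 570 nM, and the step of a 1.3-fold lower number from compound 1 to compound 3 (0.12 log units; within the scatter) lies within the scatter. Compound 4 `CC(C)=CCC[C@]1(C)/C=C/[C@@H](OC(=O)C=C(C)C)[C@](C)(O)/C=C/C(=O)/C(C(=O)N(C(C)C)C(C)C)=C\C1` differs from compound 1 at the same chain carbon: diisopropylcarbamoyl in place of (diisopropylamino)methyl on a double-bonded ring carbon. Going by the values given here, only the step from compound 1 to compound 3 bears on this change, and it was within the scatter, so no step beyond the scatter is expected in this assay. Compound 4 is therefore estimated at 1000 nM, between 350 nM and 3000 nM, a step of a 1.3-fold higher number from compound 1 to compound 4 (0.12 log units; within the scatter).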

Compound 4, half-maximal inhibitory concentration: 16000 nM
The estimate for compound 4 lay 16-fold (1.20 log units) below the measured number; measured number above the stated range.
By their numbers in this assay, from the lowest: compounds 3 and 1 (each within the scatter of the next); then compound 4. At a limit, above all of these: compound 2.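

In this assay, the change from (diisopropylamino)methyl to diisopropylcarbamoyl on this double-bonded ring carbon gives a 21-fold higher number from compound 1 to compound 4 (1.33 log units; beyond the scatter), so this position does not tolerate every group, which a 1.3-fold lower number from compound 1 to compound 3 (0.12 log units; within the scatter) could not show. The step separates two groups that both carry diisopropyl on nitrogen, and the entering group adds a carbonyl. Nothing shown accounts for the size of this step. The compounds shown leave open whether the carbonyl itself or this particular amide governs the result. A carboxylic acid or dimethylcarbamoyl on this carbon would speak to that.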